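The source may report more compounds than this note shows. Statements on the series, on what has been measured and on what is new or still open speak of the compounds shown alone.

Measured so far in an ADME assay (liver) for metabolic stability, with Liver microsome (Homo sapiens) as the target, read by LC-MS, using microsomes and NADPH, with a stated time of 5 min, at 37 degrees C; a lower number here means slower removal, a higher number faster removal of the compound:
- Compound 1 `CCn1c([C@@H](C)NS(=O)(=O)c2cccc(C#N)c2)nc2ccc(C(F)(F)F)cc21`: > 100 mL.min-1.g-1, a limit
- Compound 2 `CCn1c([C@@H](C)NS(=O)(=O)c2ccc(CC(C)C)cc2)nc2ccc(C(F)(F)F)cc21`: > 100 mL.min-1.g-1, a limit

Compound 2 has no exact number, only the limit > 100 mL.min-1.g-1. Compound 3 `CCn1cc(S(=O)(=O)N[C@H](C)c2nc3ccc(C(F)(F)F)cc3n2CC)cn1` differs from it on the sulfonyl sulfur: 1-ethyl-1H-pyrazol-4-yl in place of 4-isobutylphenyl on a sulfonyl sulfur. Going by the values given here, the one measured change at this place is a step that the two limits leave unreadable from compound 1 to compound 2, so it offers no size to carry over. Both measured compounds sit at the limit of > 100 mL.min-1.g-1 in this assay, at which 2 of the 2 values shown sit. A number from this assay for compound 3 could only lie lower, so a modest fall is expected, though it may remain at the limit. The expected change is an at least 1.4-fold lower number from compound 2 to compound 3 (0.15 log units; that floor lies within the scatter). For compound 3 the estimated value is 70 mL.min-1.g-1, with an expected range of 25 mL.min-1.g-1 to 100 mL.min-1.g-1.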

Compound 3, intrinsic clearance in microsomes: 95 mL.min-1.g-1
Compound 3: middle estimate off by 1.4-fold (0.13 log units), on the low side, and the stated range covers the measured number.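

In this assay, going by these compounds alone, compound 3, with its 1-ethyl-1H-pyrazol-4-yl group on the sulfonyl sulfur, gives the first exact number at this place, 95 mL.min-1.g-1. The steps to it are an at least 1.0-fold lower number from compound 2 to compound 3 (0.02 log units; that floor lies within the scatter) and an at least 1.0-fold lower number from compound 1 to compound 3 (0.02 log units; that floor lies within the scatter), so this change is not shown to slow removal beyond the usual scatter. The step between compound 1 and compound 2 cannot be read, and most of the values remain a limit: the limit of > 100 mL.min-1.g-1 in this assay, at which 2 of the 3 values shown sit.

On these data alone, it remains open whether a phenyl ring carrying a carboxylic acid or an amine would bring the number clearly lower. The same question stands for a pyrazole with a longer chain in place of the ethyl.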